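Aryl urea in place of the hydroxypentyl tail

The source may report more compounds than this note shows. Statements on the series, on what has been measured and on what is new or still open speak of the compounds shown alone.

Measured so far:
compound 1, `COc1cc(NC(C)CCCNC(=O)NNC(=O)NCCCCCO)c2ncccc2c1`, 54%
compound 2, `O=C(NC(c1ccccc1)c1ccc(Cl)cc1)NC(c1ccccc1)c1ccc(Cl)cc1`, 33%
compound 3, `NNC(=O)NC(c1ccccc1)c1ccc(Cl)cc1`, 52%

Three compounds have been run in a physicochemical assay for inhibition, read by spectrophotometry, tested at 100 uM; a lower number here means less inhibition, a higher number more inhibition at the concentration tested (going by the name of the read-out). Compound 1 gives the highest of the three numbers, but its nearest neighbour, compound 3, lies within the usual scatter of it, so the two cannot be ordered. Compound 2 sits well beyond the scatter, and of the two diarylmethyl ureas the one carrying the hydrazide, compound 3, returns the higher reading.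

Compound 4, `COc1cc(NC(C)CCCNC(=O)Nc2ccc(Cl)c(C(F)(F)F)c2)c2ncccc2c1`, has not yet been measured in this assay. It differs from compound 1 in one place: 4-chloro-3-(trifluoromethyl)phenyl in place of ((5-hydroxypentyl)carbamoyl)amino on an amide-type nitrogen. The tail that carries the carbamoyl-amino link is removed and a bare aromatic ring takes its place. For the measured compounds named here, no measured pair maps this change directly, so the expectation rests on the gap between compound 2 and compound 3, where the aryl-rich urea without a hydrazide reads lower. The step from compound 1 is therefore expected to be downward, about the size of the scatter: a number 14 percentage points lower from compound 1 to compound 4 (beyond the scatter). Compound 4 is estimated at 40%, with a range from 20% to 60%.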

Compound 4, a percentage reported as inhibition, at one concentration (the size of the read-out at that concentration, not a potency): 61%
The estimate for compound 4 lay 21 percentage points below the measured number, outside the stated range (above it).
By their numbers in this assay, from the lowest: compound 2; then compounds 3, 1 and 4 (each within the scatter of the next).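

In this assay the replacement of ((5-hydroxypentyl)carbamoyl)amino by 4-chloro-3-(trifluoromethyl)phenyl on the amide-type nitrogen amounts to a number 7 percentage points higher from compound 1 to compound 4 (within the scatter) and so does not separate the two groups. This position therefore accepts the loss of a ringless chain carrying hydrogen-bond donors and acceptors, and the entry of a six-membered aromatic ring of carbon only with neither, without a step beyond the scatter. Nothing available explains this outcome.

As far as these compounds go, whether the same holds for other groups on this nitrogen, such as a plain phenyl ring, an amine, a carboxylic acid or a longer chain, remains open. The compounds shown also leave open whether the chlorine or the trifluoromethyl contributes to the reading of compound 4 on its own.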